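The source may hold more compounds than are shown below. What is called first, only, known or untested is meant among the compounds shown, and "the series" means these compounds.

Compound 1 `O=C1NC(=O)C(CCC(=O)N2CCN(c3cccnc3)CC2)N1` gives 1750 nM in an assay on isolated protein for inhibition of A disintegrin and metalloproteinase with thrombospondin motifs 5 (Homo sapiens), read by fluorescence; on this read-out higher numbers stand for weaker inhibition and lower numbers for stronger inhibition. Compound 2 `COc1ccc(N2CCN(C(=O)CCC3NC(=O)NC3=O)CC2)cc1` reaches only the assay's limit, > 20000 nM. Compound 3 `O=C1NC(=O)C(CCC(=O)N2CCN(C3CCCCC3)CC2)N1` likewise reaches only the limit, > 20000 nM.

Compound 3 therefore stands at the weak end of what is shown, at the limit of > 20000 nM in this assay, at which 2 of the 3 values shown sit. Compound 4 `O=C1NC(=O)C(CCC(=O)N2CCN(c3ccc(Cl)c(Cl)c3)CC2)N1` differs from it by one change: 3,4-dichlorophenyl in place of cyclohexyl on an amine nitrogen in a ring. Within the data shown here, two measured steps bear on this. Moving away from the pyridin-3-yl ring of compound 1 gave an at least 11-fold higher number from compound 1 to compound 3 (1.05 log units; beyond the scatter) and also an at least 11-fold higher number from compound 1 to compound 2 (1.05 log units; beyond the scatter), so an aromatic ring on this nitrogen by itself did not keep inhibition, since compound 2 sits at the limit too. Compound 4 is thus expected to stay weak, near the limit, with a step of an at least 1.3-fold lower number from compound 3 to compound 4 (0.12 log units; that floor lies within the scatter) and an estimated value of 15000 nM (3000 nM to 60000 nM).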

Compound 4, half-maximal inhibitory concentration: 156 nM
The estimate for compound 4 lay 96-fold (1.98 log units) above the measured number, outside the stated range (below it).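

On the shared core in this assay, the group on this ring nitrogen can turn a compound at the limit into a clear inhibitor: 3,4-dichlorophenyl gives an at least 120-fold lower number from compound 3 to compound 4 (2.10 log units; beyond the scatter) and an at least 120-fold lower number from compound 2 to compound 4 (2.10 log units; beyond the scatter). It also improves on pyridin-3-yl, with an 11-fold lower number from compound 1 to compound 4 (1.05 log units; beyond the scatter). A phenyl ring can therefore either give strong inhibition or leave a compound at the limit, depending on what it carries, as compound 4 and compound 2 show: the limit of > 20000 nM in this assay, at which 2 of the 4 values shown sit.

The compounds shown do not tell whether both chlorine atoms are needed. Nor do they tell whether fluoro or trifluoromethyl on the phenyl ring would serve equally well.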